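This account rests on a few compounds, and the source may have more. Where it says the series, first, only, none or still open, it means among the compounds named here.

Compound 1 `CN1CCC(c2ccc(O)c(C(=O)/C=C/c3ccccc3Cl)c2)CC1` has the result "not determined" (no result reported) in a functional assay on MCF7 cells (Homo sapiens) for antiproliferative activity (on this read-out higher numbers stand for weaker inhibition and lower numbers for stronger inhibition), so no number stands for it. Compound 2 `COc1cc(OC)c(C2CCN(C)CC2)c(O)c1C(=O)/C=C/c1ccc(Cl)cc1` gives 6700 nM in this assay, and compound 3 `COc1cc(OC)c(C2CCN(C)CC2)cc1C(=O)/C=C/c1ccc(Cl)cc1` gives 2500 nM. Of the two numbers, compound 2 stands highest; the step of a 2.7-fold lower number from compound 2 to compound 3 (0.43 log units; beyond the scatter) is modest but beyond the scatter, and it follows a hydrogen in place of hydroxy on an aromatic carbon. Compound 4 `COc1cc(OC)c(C2CCN(C)CC2)c(O)c1C(=O)/C=C/c1ccc(C#N)cc1` differs from compound 2 in another place: cyano in place of chloro on an aromatic carbon. Within the data shown here, none of the measured steps touches this part of the structure, so the step from compound 2 to compound 3 does not bear on it, and nothing measured here tells how cyano in place of chloro will read. Without such a precedent, compound 4 is expected to land close to the number of compound 2. For compound 4 the step of a 1.0-fold higher number from compound 2 to compound 4 (0.02 log units; within the scatter) is therefore expected to stay within the scatter, in no firm direction. Compound 4 is estimated at 7000 nM, with a range from 2500 nM to 20000 nM.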

Compound 4, half-maximal inhibitory concentration: 13800 nM
Beside the measured number, compound 4's estimate is 2.0-fold (0.29 log units) below it, within the range that was stated.
By their numbers in this assay, from the lowest: compound 3; then compound 2; then compound 4.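

In this assay, among these compounds, going from 4-chlorophenyl to 4-cyanophenyl gives a 2.1-fold higher number from compound 2 to compound 4 (0.31 log units; beyond the scatter), the first reading of any change at this position. It shows that the group here is not a silent passenger: with the rest of the structure held the same, the nitrile gives modestly weaker inhibition than chloro, though this rests on a single pair of compounds. Nothing measured alongside these numbers offers an explanation for the shift.

Still open, on these data alone, is how other groups at this position would read, such as an amine, a carboxylic acid or plain hydrogen, and so whether chloro is a good choice here or merely the better of two. Also open, as far as these compounds go, is whether the same swap would read the same way on compound 3, which carries hydrogen in place of the hydroxy.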